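Sulfonamide aryl swap on an octadecyl threonine amide

The source may report more compounds than this note shows. Statements on the series, on what has been measured and on what is new or still open speak of the compounds shown alone.

The series shares the core of compound 1 `CCCCCCCCCCCCCCCCCCNC(=O)[C@@H](N)[C@@H](C)O`, which in a functional assay on SW-620 cells (Homo sapiens) for cytotoxicity, read by MTT assay, with a stated time of 48 h (a higher number here means a weaker inhibitor, a lower number a stronger inhibitor), gives 21400 nM. Compound 2 `CCCCCCCCCCCCCCCCCCNC(=O)[C@@H](NS(=O)(=O)c1ccc(C)cc1)[C@@H](C)O` carries a sulfonyl on the amine nitrogen and in this assay gives 32500 nM; the step of a 1.5-fold higher number from compound 1 to compound 2 (0.18 log units; within the scatter) is within the scatter, so on the two numbers shown compound 2 and compound 1 are not separable. Compound 3 `CCCCCCCCCCCCCCCCCCNC(=O)[C@@H](NS(=O)(=O)c1ccc2ccccc2c1)[C@@H](C)O` differs from compound 2 by naphthalen-2-yl in place of 4-methylphenyl on a sulfonyl sulfur. Among the compounds with values here, no measured step changes the group on the sulfonyl sulfur; the only step in hand, a 1.5-fold higher number from compound 1 to compound 2 (0.18 log units; within the scatter), adds the whole sulfonyl and stays within the scatter, so there is no basis for expecting a shift beyond the scatter in this assay in either direction. Compound 3 is therefore expected to give about 30000 nM, with a range of 10000 nM to 90000 nM, which amounts to an expected step of a 1.1-fold lower number from compound 2 to compound 3 (0.03 log units; within the scatter).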

Compound 3, half-maximal inhibitory concentration: 24600 nM
Beside the measured number, compound 3's estimate is 1.2-fold (0.09 log units) above it; low and high end bracket the measured number.
By their numbers in this assay, from the lowest: compounds 1, 3 and 2 (each within the scatter of the next).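

Naphthalen-2-yl in place of 4-methylphenyl on a sulfonyl sulfur gives a 1.3-fold lower number from compound 2 to compound 3 (0.12 log units; within the scatter) in this assay and stays within the scatter. Within the data shown here, earlier, the only step added the whole sulfonyl; this one changes the group on the sulfur itself, from one six-membered aromatic ring of carbon only to 2 such rings, and the read-out does not separate the two groups. Nothing available bears on why the number does not separate them.

Going by these compounds, both groups compared here are carbon only, with no hydrogen-bond donors or acceptors, so it remains open whether an aryl group carrying an amine or a carboxylic acid on the sulfonyl sulfur would give a step beyond the scatter. Also open, on these data alone, is how a shorter chain in place of the octadecyl chain would read in this assay with either sulfonamide.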